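The source may report more compounds than this note shows. Statements on the series, on what has been measured and on what is new or still open speak of the compounds shown alone.

Measured so far in a functional assay on MCF7 cells (Homo sapiens) for cytotoxicity, read by MTT assay, with a stated time of 72 h; a lower number here means a stronger inhibitor of growth, a higher number a weaker inhibitor of growth:
Compound 1 `CSc1ccc(CNc2nc(SC)nc3ncccc23)cc1` gives 4370 nM.
Compound 2 `COc1ccc(CNc2nc(SC)nc3ncccc23)cc1` gives > 100000 nM, a limit of the assay.
Compound 3 `CSc1nc(NCCCCCO)c2cccnc2n1` gives > 100000 nM, likewise a limit of the assay.

Compound 3 therefore stands at the limit of > 100000 nM in this assay, at which 2 of the 3 values shown sit, and no number is known for it. Compound 4 `CSc1nc(NCc2ccccc2)c2cccnc2n1` differs from compound 3 by phenyl in place of 4-hydroxybutyl on a saturated chain carbon bound to a nitrogen on an aromatic ring. Going by the values given here, no measured step follows this change. Among the compounds with values here, the one measured step, an at least 22-fold higher number from compound 1 to compound 2 (1.35 log units; beyond the scatter), alters a substituent on the benzyl ring rather than the chain itself and so bears only indirectly; it shows that benzyl analogues of this core can range from a clear number to the limit. Since compound 3 gives only a limit, the size of the expected step of an at least 3.3-fold lower number from compound 3 to compound 4 (0.52 log units; beyond the scatter) cannot be fixed from it. Compound 4 is expected to give 30000 nM, in the range 5000 nM to 100000 nM, with a real chance of returning only a limit.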

Compound 4, concentration for total growth inhibition: > 100000 nM
Compound 4: no number, only a limit; the forecaster's own chance of this, stated with the estimate: 45%; middle value at least 3.3-fold (0.52 log units) from the limit.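

In this assay, hydrogen in place of methylsulfanyl on an aromatic carbon gives an at least 22-fold higher number from compound 1 to compound 4 (1.35 log units; beyond the scatter), so the plain benzyl analogue offers no number and, among the benzyl compounds shown, only compound 1 has one. The steps to compound 4 from compound 2 and from compound 3 cannot be read, as both ends are limits. Phenyl in place of 4-hydroxybutyl therefore shows no readable gain, and compound 4 joins the others at the ceiling: the limit of > 100000 nM in this assay, at which 3 of the 4 values shown sit.

Open, from the compounds shown here alone, is whether ethylsulfanyl or an amine on the benzyl ring would also give a number. Also open, going by these compounds, is how far the compounds at the limit lie beyond it.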